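Acrylamide headgroup variation on a shared anilinoquinazoline core

The source may hold more compounds than are shown below. What is called first, only, known or untested is meant among the compounds shown, and "the series" means these compounds.

Measured so far:
Compound 1 `O=C(/C=C/c1cccnc1)Nc1ccc2ncnc(Nc3cccc(Cl)c3)c2c1`: 9120 nM
Compound 2 `O=C(/C=C/c1cccc(Br)n1)Nc1ccc2ncnc(Nc3cccc(Cl)c3)c2c1`: 10700 nM

In a functional assay on HepG2 cells (Homo sapiens) for antiproliferative activity, read by MTT assay, with a stated time of 48 h (a lower number here means a stronger inhibitor, a higher number a weaker inhibitor), compound 2 gives the highest of the two numbers, with compound 1 nearest at 9120 nM; the step of a 1.2-fold higher number from compound 1 to compound 2 (0.07 log units; within the scatter) lies within the scatter. Compound 3 `O=C(/C=C/c1ncc2ccccc2n1)Nc1ccc2ncnc(Nc3cccc(Cl)c3)c2c1` carries quinazolin-2-yl in place of 6-bromopyridin-2-yl on a double-bonded chain carbon bound to a double-bonded chain carbon. Within the data shown here, only the step from compound 1 to compound 2 bears on a change at this chain carbon, and it was within the scatter, so no step beyond the scatter is expected here either. Compound 3 is therefore estimated at 10000 nM (range 3500 nM to 30000 nM), an expected step of a 1.1-fold lower number from compound 2 to compound 3 (0.03 log units; within the scatter).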

Compound 3, half-maximal inhibitory concentration: 7790 nM
Compound 3: the middle estimate sits 1.3-fold (0.11 log units) above what was measured; measured number inside the range.
By their numbers in this assay, from the lowest: compounds 3, 1 and 2 (each within the scatter of the next).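

In this assay, two aromatic rings at this chain carbon read no differently from one: quinazolin-2-yl in place of 6-bromopyridin-2-yl gives (a 1.4-fold lower number from compound 2 to compound 3 (0.14 log units; within the scatter)), and in place of pyridin-3-yl gives (a 1.2-fold lower number from compound 1 to compound 3 (0.07 log units; within the scatter)). The position therefore accepts 10 heavy atoms as well as 7, and a group without bromine as well as one with it, with no step beyond the scatter. No measurement bears on why these groups read alike. On these data alone, whether any group here gives a step beyond the scatter stays open, for instance an amine or a carboxylic acid at this chain carbon.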